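This account rests on a few compounds, and the source may have more. Where it says the series, first, only, none or still open, it means among the compounds named here.

In a functional assay on HeLa cells (Homo sapiens) for antiproliferative activity, read by MTT assay, with a stated time of 48 h (on this read-out higher numbers stand for weaker inhibition and lower numbers for stronger inhibition), compound 3 `Cc1ccc2[nH]c(-c3cn(-c4ccccc4)nc3-c3ccc(F)cc3)nc2c1` gives 3630 nM. That number lies within the usual scatter of compound 1 `FC(F)(F)c1ccc2[nH]c(-c3cn(-c4ccccc4)nc3-c3ccccc3)nc2c1` at 1920 nM, while compound 2 `COc1ccc2[nH]c(-c3cn(-c4ccccc4)nc3-c3ccc(F)cc3)nc2c1` stands clearly higher at 7510 nM.

Compound 4 `Fc1ccc(-c2nn(-c3ccccc3)cc2-c2nc3cc(C(F)(F)F)ccc3[nH]2)cc1` keeps the structure of compound 3 except for one change, trifluoromethyl in place of methyl on an aromatic carbon. Among the measured compounds shown here, only one measured step involves this carbon: a 2.1-fold lower number from compound 2 to compound 3 (0.32 log units; beyond the scatter). This modest step, with methyl in place of methoxy, shows that the number can move with a change here, but it does not test trifluoromethyl. Compound 1 does carry trifluoromethyl and gives 1920 nM, yet it also differs from compound 4 elsewhere, so it is only a rough guide. A small step toward a lower number is therefore expected in this assay, and it may not exceed the scatter. The estimated change is a 1.5-fold lower number from compound 3 to compound 4 (0.16 log units; within the scatter). For compound 4, the expected value is 2500 nM, with an estimated range from 1000 nM to 6000 nM.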

Compound 4, half-maximal inhibitory concentration: 3520 nM
The estimate for compound 4 lay 1.4-fold (0.15 log units) below the measured number; the range from low to high includes it.
By their numbers in this assay, from the lowest: compounds 1, 4 and 3 (each within the scatter of the next); then compound 2.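

In this assay, trifluoromethyl in place of methyl on this aromatic carbon gives a 1.0-fold lower number from compound 3 to compound 4 (0.01 log units; within the scatter), so the two groups cannot be told apart here. Trifluoromethyl in place of methoxy gives a 2.1-fold lower number from compound 2 to compound 4 (0.33 log units; beyond the scatter), a modest step much like the one seen with methyl, so among these three groups only the methoxy of compound 2 stands apart. A separate change, fluoro in place of hydrogen on an aromatic carbon, gives a 1.8-fold higher number from compound 1 to compound 4 (0.26 log units; within the scatter), so that swap also cannot be told from the scatter on this pair.

No measured evidence is available to explain why methyl and trifluoromethyl match at this carbon. From the compounds shown here alone, whether a group of a different kind here, such as an amine or a carboxylic acid, would move the number further remains open.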